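Fluoro to chloro on the aryl group of compound 2

The source may report more compounds than this note shows. Statements on the series, on what has been measured and on what is new or still open speak of the compounds shown alone.

Measured compounds:
- Compound 1, `O=C(Nc1ccc(Oc2ccnc3[nH]ccc23)cc1)c1cn(-c2ccccc2)c2ccccc2c1=O`: 3560 nM
- Compound 2, `O=C(Nc1ccc(Oc2ccnc3[nH]ccc23)cc1)c1cn(-c2ccc(F)cc2)c2ccccc2c1=O`: 720 nM

Both compounds share one core and differ only on the aromatic ring attached to the nitrogen of that core. In a functional assay on MCF7 cells (Homo sapiens) for inhibition, read by MTT assay, with a stated time of 72 h (on this read-out higher numbers stand for weaker inhibition and lower numbers for stronger inhibition), compound 1 gives 3560 nM, while compound 2 gives 720 nM. Compound 2 therefore holds the lower of the two numbers, and the step of a 4.9-fold lower number from compound 1 to compound 2 (0.69 log units; beyond the scatter) is beyond the usual scatter.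

Compound 3, `O=C(Nc1ccc(Oc2ccnc3[nH]ccc23)cc1)c1cn(-c2ccc(Cl)cc2)c2ccccc2c1=O`, has not yet been measured. It differs from compound 2 by chloro in place of fluoro on an aromatic carbon, that is, a chloro group now sits where the fluoro group sat. Among the compounds with values here, only one measured step bears on this change, the one from compound 1 to compound 2, which shows that placing a halogen on this ring lowered the number. Whether a chloro group behaves like a fluoro group here is not known from these two compounds, so the expected step of a 1.4-fold lower number from compound 2 to compound 3 (0.16 log units; within the scatter) is small, most likely within the scatter. Compound 3 is estimated at 500 nM in this assay, with a range from 150 nM to 1800 nM.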

Compound 3, half-maximal inhibitory concentration: 1590 nM
For compound 3 the middle estimate is 3.2-fold (0.50 log units) below the measured one; measured number inside the range.
By their numbers in this assay, from the lowest: compound 2; then compound 3; then compound 1.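

In this assay, the two halogens do not behave alike on this ring: going from fluoro to chloro gives a 2.2-fold higher number from compound 2 to compound 3 (0.34 log units; beyond the scatter), so which halogen sits at this place matters and not only whether one is present. Chloro still improves on the unsubstituted phenyl ring, with a 2.2-fold lower number from compound 1 to compound 3 (0.35 log units; beyond the scatter), so among these three compounds both halogens give a lower number than hydrogen, and the 4-fluorophenyl group gives the lowest. No measurement shown here offers an explanation for the gap between compound 2 and compound 3.

From the compounds shown here alone, three substituents at a single place cannot show a trend, so it remains open how a bromo group, a methoxy group, a methyl group or an amine would compare with fluoro on this ring. Also open, going by these compounds, is whether the number reflects action at one molecular target, since this cell read-out alone does not separate that from other effects on the cells, and whether the same halogen order would hold in other cell lines.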